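Sulfonamide series, C-C chemokine receptor type 8 binding

A few compounds are considered here, and "the series" means these few. Any claim that something is new, unique, unknown or untested is made for them only; others in the source may bear on it.

Measured so far:
compound 1 `CCOC(=O)N1CCC(NS(=O)(=O)c2ccc(NC(=O)c3ccccc3)c3ccccc23)CC1` — 0.17 nM
compound 2 `Cc1ccccc1C(=O)Nc1ccc(S(=O)(=O)NC2CCN(C(=O)C3CCCC3)CC2)c2ccccc12` — 9.1 nM

In an assay on L1.2 cells for binding affinity to C-C chemokine receptor type 8 (Homo sapiens) (on this read-out lower numbers stand for stronger inhibition and higher numbers for weaker inhibition), compound 1 gives 0.17 nM and compound 2 gives 9.1 nM. Compound 2 thus stands as the higher of the two numbers, the weaker binder, with compound 1 well apart from it by more than the usual scatter. Within the data shown here, the two share the naphthalene sulfonamide and the piperidine, but differ at two places, so no single step between them can be read.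

Compound 3 `Cc1ccccc1C(=O)Nc1ccc(S(=O)(=O)NC2CCN(C(=O)N(C)C)CC2)c2ccccc12` is the next member: dimethylamino in place of cyclopentyl on a carbonyl carbon. The acyl group on the ring nitrogen is exchanged, the rest of compound 2 is kept. The data hold no earlier change of this kind, so the direction is open; a step from compound 2 to compound 3 of a 1.5-fold lower number from compound 2 to compound 3 (0.18 log units; within the scatter) is expected, small and not clearly beyond the scatter. Compound 3 is estimated at 6 nM, within 1.5 nM to 30 nM.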

Compound 3, inhibition constant: 1.6 nM
The estimate for compound 3 lay 3.8-fold (0.57 log units) above the measured number; measured number inside the range.
By their numbers in this assay, from the lowest: compound 1; then compound 3; then compound 2.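

In this assay, among these compounds, dimethylamino in place of cyclopentyl on the carbonyl carbon gives a 5.7-fold lower number from compound 2 to compound 3 (0.75 log units; beyond the scatter), the first step that can be read at a single place. It shows that the group on this carbonyl carbon affects the read-out beyond the scatter, and that a group with no ring is accepted here in place of a five-membered ring of carbon only. No measurement on hand accounts for the step, and this one pair cannot separate the loss of the ring from the entry of the nitrogen.

As far as these compounds go, whether pyrrolidin-1-yl, which keeps a ring and the nitrogen on the carbonyl carbon, would stay close to compound 3 or to compound 2 remains open. Steps involving compound 1 cannot be read, so the contribution of an ethoxy group at this carbonyl carbon also remains open.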